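A 6-chloropyridin-3-yl swap on the sulfonyl sulfur

A few compounds are considered here, and "the series" means these few. Any claim that something is new, unique, unknown or untested is made for them only; others in the source may bear on it.

In an ADME assay on HCT-116 cells (Homo sapiens) for cytotoxicity, read by CellTiter-Glo, with a stated time of 72 h (a lower number here means a stronger inhibitor, a higher number a weaker inhibitor), compound 3 `Cc1ccc(S(=O)(=O)N2CCC(N3CCC(C)CC3)CC2)cc1C` gives > 5000 nM as a limit and not as a number. Compound 2 `CC1CCN(C2CCN(S(=O)(=O)c3cccc(N)c3)CC2)CC1` gives > 5000 nM as a limit too. Compound 1 `CC1CCN(C2CCN(S(=O)(=O)c3cccnc3Cl)CC2)CC1` likewise gives > 10000 nM as a limit of the assay. Compound 4 `CC1CCN(C2CCN(S(=O)(=O)c3ccc(Cl)nc3)CC2)CC1` carries 6-chloropyridin-3-yl in place of 3,4-dimethylphenyl on a sulfonyl sulfur on the same core. Two measured changes bear on this swap, a step that the two limits leave unreadable from compound 1 to compound 3 and a step that the two limits leave unreadable from compound 2 to compound 3, and neither offers a size to carry over. No change beyond the scatter is therefore expected in this assay, and the estimated step is a step that the limit leaves unreadable from compound 3 to compound 4 at most in name. Compound 4 is expected at 10000 nM within a range of 5000 nM to 20000 nM and will probably be reported only as a limit.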

Compound 4, half-maximal inhibitory concentration: > 10000 nM
Compound 4: only a limit was reported; the forecaster's own chance of this, stated with the estimate: 90%; the middle value lies on the limit itself.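

In this assay compound 4 also gives only a limit, so its steps from compound 1, compound 2 and compound 3 cannot be read. As far as these compounds go, whether these four compounds truly differ there remains open.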